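From butyl to 4-methoxyphenyl on the sulfonyl sulfur

This account rests on a few compounds, and the source may have more. Where it says the series, first, only, none or still open, it means among the compounds named here.

In a functional assay on Huh-7 cells (Homo sapiens) for cytotoxicity, read by MTT assay, with a stated time of 72 h (on this read-out higher numbers stand for lower toxicity in this test and lower numbers for higher toxicity in this test), compound 1 `CS(=O)(=O)N1CCC2(CC1)OOC1(CCCCC1)OO2` gives > 100 ug/mL, which is a limit and not a number. Compound 2 `CCCS(=O)(=O)N1CCC2(CC1)OOC1(CCCCC1)OO2` also gives a limit, > 100 ug/mL. Compound 3 `CCCCS(=O)(=O)N1CCC2(CC1)OOC1(CCCCC1)OO2` likewise gives only a limit, > 100 ug/mL. That is the limit of > 100 ug/mL in this assay, at which 3 of the 3 values shown sit.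

Compound 4 `COc1ccc(S(=O)(=O)N2CCC3(CC2)OOC2(CCCCC2)OO3)cc1` carries one change: 4-methoxyphenyl in place of butyl on a sulfonyl sulfur. The measured steps that bear on it all alter the chain at that sulfur: a step that the two limits leave unreadable from compound 1 to compound 2, a step that the two limits leave unreadable from compound 1 to compound 3 and a step that the two limits leave unreadable from compound 2 to compound 3. None has a readable size, and none brings in an aromatic ring. The expected result is a number no higher from compound 3 to compound 4 (the limit leaves the size open), so no clear change beyond the scatter and no favoured direction are expected. Compound 4 is estimated at 100 ug/mL, within a range of 40 ug/mL to 200 ug/mL.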

Compound 4, half-maximal cytotoxic concentration: > 100 ug/mL
Compound 4 ended at the assay's limit; the forecaster's own chance of this, stated with the estimate: 65%; the middle value sits exactly at the limit.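

No step between compound 1, compound 2, compound 3 and compound 4 can be read, because each value is a limit and not a number: the limit of > 100 ug/mL in this assay, at which 4 of the 4 values shown sit.

As far as these compounds go, whether any of these groups on the sulfonyl sulfur changes the result in this assay, and by how much, stays open.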